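This account rests on a few compounds, and the source may have more. Where it says the series, first, only, none or still open, it means among the compounds named here.

Measured compounds and their values in a functional assay on A549 cells (Homo sapiens) for cytotoxicity, read by MTT assay; on this read-out lower numbers stand for stronger inhibition and higher numbers for weaker inhibition:

Compound 1, `N#Cc1c(-c2ccc(F)cc2)cc(-c2c(O)c3ccccc3oc2=O)nc1N`: 22300 nM
Compound 2, `N#Cc1c(-c2c(F)cccc2Cl)cc(-c2c(O)c3ccccc3oc2=O)nc1N`: 46300 nM
Compound 3, `O=c1oc2ccccc2c(O)c1-c1cc(-c2ccc(F)cc2)nc(S)n1`: 21100 nM

The step from compound 1 to compound 2 is the change (2-chloro-6-fluorophenyl in place of 4-fluorophenyl on an aromatic carbon), and in this assay it gave a 2.1-fold higher number from compound 1 to compound 2 (0.32 log units; beyond the scatter). Compound 3 shares the coumarin-bearing side of compound 1 but carries a different core; the difference between the two cores is not broken down here. In this assay compound 3 gives a number that lies within the scatter of compound 1, so the two are not told apart, while compound 2 stands beyond the scatter of both.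

Compound 4, `O=c1oc2ccccc2c(O)c1-c1cc(-c2c(F)cccc2Cl)nc(S)n1`, has not yet been measured in this assay. It differs from compound 3 by 2-chloro-6-fluorophenyl in place of 4-fluorophenyl on an aromatic carbon. Going by the values given here, this is the same kind of change as the one from compound 1 to compound 2, but the place is not the same: in compound 1 the group sits on a six-membered aromatic ring with 1 nitrogen, ortho to a cyano group and meta to an amino group, whereas in compound 3 it sits on a six-membered aromatic ring with 2 nitrogen, next to the ring nitrogen and meta to a sulfanyl group. The expectation for compound 4 rests on one precedent only, so it is held loosely. Compound 4 is expected to show a step of a 2.1-fold higher number from compound 3 to compound 4 (0.33 log units; beyond the scatter), because the analogous change gave a 2.1-fold higher number from compound 1 to compound 2 (0.32 log units; beyond the scatter) on a core that is otherwise closely related. Compound 4 is therefore estimated at 45000 nM, with a plausible range from 24000 nM to 90000 nM.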

Compound 4, half-maximal inhibitory concentration: 3980 nM
Estimate against measurement, compound 4: 11-fold (1.05 log units) above; the whole stated range lies above it.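

In this assay, putting 2-chloro-6-fluorophenyl in place of 4-fluorophenyl on the core of compound 3 gave a 5.3-fold lower number from compound 3 to compound 4 (0.72 log units; beyond the scatter), whereas on the core of compound 1 the same change gave a 2.1-fold higher number from compound 1 to compound 2 (0.32 log units; beyond the scatter). Going by these compounds alone, the change therefore does not carry from one core to the other, and even the direction of its step differs between them: the same change on two cores in this assay, a 2.1-fold higher number (0.32 log units; beyond the scatter) from compound 1 to compound 2 and a 5.3-fold lower number (0.72 log units; beyond the scatter) from compound 3 to compound 4, 11-fold (1.04 log units) apart, beyond the scatter of two such steps With only one pair on each core, this shows that the outcome of the change depends on its setting, but it does not show which difference between the cores matters, or whether any other aryl group would behave in the same way.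

The compounds shown leave open whether the lower number of compound 4 would survive a methyl or methoxy group in place of the sulfanyl group on its core. They also leave open whether the step on that core would remain with a phenyl group carrying only the chlorine or only the fluorine of the 2-chloro-6-fluorophenyl group.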